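The source may report more compounds than this note shows. Statements on the series, on what has been measured and on what is new or still open speak of the compounds shown alone.

Compound 1 `Cc1cccc(-n2nncc2CN2C(=O)C3(C(C#N)=C(N)Oc4c(N)cc5nc6ccccc6nc5c43)c3ccccc32)c1`: in a functional assay on MCF7 cells (Homo sapiens) for antiproliferative activity, read by MTT assay, with a stated time of 48 h (a lower number here means a stronger inhibitor, a higher number a weaker inhibitor), compound 1 gives only a limit of the assay, > 50000 nM.
Compound 2 `N#CC1=C(N)Oc2c(N)cc3nc4ccccc4nc3c2C12C(=O)N(Cc1cnnn1-c1ccc(F)cc1)c1ccccc12`: compound 2 likewise gives only a limit, > 50000 nM.
Compound 3 `N#CC1=C(N)Oc2c(N)cc3nc4ccccc4nc3c2C12C(=O)N(Cc1cnnn1-c1ccccc1Br)c1ccccc12`: compound 3 gives 30700 nM.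

Among the measured compounds shown here, compound 3 thus stands as the only real number among the three; the other two values are limits (the limit of > 50000 nM in this assay, at which 2 of the 3 values shown sit). Compound 4 `N#CC1=C(N)Oc2c(N)cc3nc4ccccc4nc3c2C12C(=O)N(Cc1cnnn1-c1cccc(C(F)(F)F)c1)c1ccccc12` differs from compound 3 in one place: 3-(trifluoromethyl)phenyl in place of 2-bromophenyl on an aromatic nitrogen. For the measured compounds named here, two measured steps bear on this position. Swapping the phenyl substituent gave an at least 1.6-fold lower number from compound 1 to compound 3 (0.21 log units; that floor lies within the scatter) and an at least 1.6-fold lower number from compound 2 to compound 3 (0.21 log units; that floor lies within the scatter), both floors within the scatter, while the step from compound 1 to compound 2 is unreadable. Compound 4 carries a 3-substituted phenyl like compound 1, so a weaker or unchanged result is expected: compound 4 is estimated at 45000 nM (range 18000 nM to 150000 nM), a step of a 1.5-fold higher number from compound 3 to compound 4 (0.17 log units; within the scatter).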

Compound 4, half-maximal inhibitory concentration: 31600 nM
Compound 4: middle estimate off by 1.4-fold (0.15 log units), on the high side; the measured number falls inside the stated range.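

In this assay, a 1.0-fold higher number from compound 3 to compound 4 (0.01 log units; within the scatter) shows that two differently substituted phenyl groups at this position give values that cannot be told apart. Compound 4 also gives a real number while carrying a 3-substituted phenyl, and its comparisons are an at least 1.5-fold lower number from compound 1 to compound 4 (0.19 log units; that floor lies within the scatter) and an at least 1.5-fold lower number from compound 2 to compound 4 (0.19 log units; that floor lies within the scatter). These two steps are floors, not sizes, as compound 1 and compound 2 give only limits: the limit of > 50000 nM in this assay, at which 2 of the 4 values shown sit.

From the compounds shown here alone, it remains open how an amine or a carboxylic acid on this phenyl ring would read out. Also open, going by these compounds, is whether a longer chain in place of the ring would do the same.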